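The source may hold more compounds than are shown below. What is called first, only, known or untested is meant among the compounds shown, and "the series" means these compounds.

Measured in a functional assay on SH-SY5Y cells (Homo sapiens) for cytotoxicity, read by MTT assay, with a stated time of 48 h; a higher number here means a weaker inhibitor, a lower number a stronger inhibitor:
- compound 1 `FC(F)=C(F)CCSc1nccs1`: > 120000 nM
- compound 2 `[O-][S+](CCC(F)=C(F)F)c1nc2ccccc2[nH]1`: > 120000 nM

In this assay compound 1 gives only a limit, > 120000 nM, not a number. Compound 2 likewise returns only a limit in this assay. Among the compounds with values here, both rest on (the limit of > 120000 nM in this assay, at which 2 of the 2 values shown sit), so no measured step exists, and compound 1 cannot be placed relative to compound 2 beyond that.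

Compound 3 `FC(F)=C(F)CCSc1ncc(Cl)s1` differs from compound 1 by chloro in place of hydrogen on an aromatic carbon. Within the data shown here, with no measured step to lean on, the expected change is none beyond the scatter; the step that the limit leaves unreadable from compound 1 to compound 3 is an estimate only. Compound 3 is expected at 200000 nM, within 60000 nM to 600000 nM, most likely again reported as a limit.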

Compound 3, half-maximal inhibitory concentration: > 120000 nM
Compound 3: a limit, no number; the forecaster's own chance of this, stated with the estimate: 75%; the middle value lies beyond the limit too.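

No step can be read from compound 1 to compound 3, as both give only limits in this assay: the limit of > 120000 nM in this assay, at which 3 of the 3 values shown sit.

The compounds shown leave open whether chloro in place of hydrogen on an aromatic carbon shifts this read-out at all.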